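A few compounds are considered here, and "the series" means these few. Any claim that something is new, unique, unknown or untested is made for them only; others in the source may bear on it.

Measured compounds:
compound 1, `CC(=O)Oc1ccc(C(=O)Nc2cc3ccc(Oc4ccc(C(C)(C)C)cc4)c(C)c3oc2=O)cc1CC=C(C)C`: 72400 nM
compound 2, `CC(C)=CCc1cc(C(=O)Nc2cc3ccc(Oc4ccc(C(C)(C)C)cc4)c(C)c3oc2=O)ccc1O`: 68300 nM

Both were tested in a functional assay on SK-BR-3 cells (Homo sapiens) for antiproliferative activity; a higher number here means a weaker inhibitor, a lower number a stronger inhibitor. Compound 2 holds the lowest of the two numbers, though the step of a 1.1-fold lower number from compound 1 to compound 2 (0.03 log units; within the scatter) means the two stand within the scatter of one another, so no order between them can be claimed. Within the data shown here, that step, hydrogen in place of acetyl on an oxygen on an aromatic ring, is the only measured step available.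

Compound 3, `COc1cc(Cc2ccc3cc(NC(=O)c4ccc(O)c(CC=C(C)C)c4)c(=O)oc3c2C)ccc1O`, has not been measured. It differs from compound 2 by 4-hydroxy-3-methoxybenzyl in place of 4-(tert-butyl)phenoxy on an aromatic carbon. Among the measured compounds shown here, the one measured step changes a different part of the shared core and is itself within the scatter, so nothing measured bears on exchanging the 4-(tert-butyl)phenoxy for the 4-hydroxy-3-methoxybenzyl. With no guide from the data, the expectation for compound 3 is a number near that of compound 2, with a wide range in both directions. The expected step is a 1.1-fold lower number from compound 2 to compound 3 (0.06 log units; within the scatter). Compound 3 is therefore estimated at 60000 nM, between 20000 nM and 200000 nM.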

Compound 3, half-maximal inhibitory concentration: 10700 nM
Compound 3: the middle estimate sits 5.6-fold (0.75 log units) above what was measured; the measured number lies below the stated range.
By their numbers in this assay, from the lowest: compound 3; then compounds 2 and 1 (each within the scatter of the next).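

In this assay, the aromatic carbon ortho to a methyl group proves sensitive to what it carries: a 6.4-fold lower number from compound 2 to compound 3 (0.81 log units; beyond the scatter) when 4-hydroxy-3-methoxybenzyl replaces 4-(tert-butyl)phenoxy. Among these compounds, this step lies beyond the scatter, whereas the only earlier step, a 1.1-fold lower number from compound 1 to compound 2 (0.03 log units; within the scatter) on removing the acetyl from an oxygen on an aromatic ring, lay within it, so this is the first change to separate two compounds. The exchange alters several features together, since the tert-butyl gives way to a hydroxy and a methoxy group and the oxygen link gives way to a benzyl carbon, and nothing among the data explains the step or assigns it to any one of these features.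

The compounds shown leave open which of these features accounts for the step, as a plain benzyl group or a 4-(tert-butyl)benzyl group at the same carbon would be needed to pull them apart. On these data alone, it also remains open whether the acetyl on the oxygen would still make so little difference with 4-hydroxy-3-methoxybenzyl in place, as that pair has been read only with 4-(tert-butyl)phenoxy.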